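Aryl for cycloalkyl on the five-membered ring

The source may hold more compounds than are shown below. What is called first, only, known or untested is meant among the compounds shown, and "the series" means these compounds.

Among the measured compounds shown here, compound 3 `O=C1O[C@H]([C@@H](O)Cn2cc(C3CC3)nn2)C(OCc2ccccc2)=C1OCc1ccccc1` gives 47700 nM in a functional assay on CFPAC-1 cells (Homo sapiens) for antiproliferative activity, read by MTT assay, with a stated time of 72 h (a higher number here means a weaker inhibitor, a lower number a stronger inhibitor), the lowest of the three numbers measured so far. Compound 2 `CC(C)(C)c1cn(C[C@H](O)[C@H]2OC(=O)C(OCc3ccccc3)=C2OCc2ccccc2)nn1` gives 54900 nM in this assay. Compound 1 `CCCCc1cn(C[C@H](O)[C@H]2OC(=O)C(OCc3ccccc3)=C2OCc2ccccc2)nn1` gives 73200 nM in this assay. The three steps between them, a 1.3-fold lower number from compound 1 to compound 2 (0.12 log units; within the scatter), a 1.5-fold lower number from compound 1 to compound 3 (0.19 log units; within the scatter) and a 1.2-fold lower number from compound 2 to compound 3 (0.06 log units; within the scatter), all lie within the scatter, so no ordering among compounds 1, 2 and 3 can be claimed.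

Compound 4 `COc1ccc(-c2cn(C[C@H](O)[C@H]3OC(=O)C(OCc4ccccc4)=C3OCc3ccccc3)nn2)cc1` differs from compound 3 as follows: 4-methoxyphenyl in place of cyclopropyl on an aromatic carbon. Every measured step exchanges one saturated group for another at this position; none introduces an aromatic group, so they bear on this change only loosely. On that basis compound 4 is expected to show no step beyond the scatter, a 1.2-fold lower number from compound 3 to compound 4 (0.08 log units; within the scatter). Compound 4 is estimated at 40000 nM, within 15000 nM to 110000 nM.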

Compound 4, half-maximal inhibitory concentration: 26000 nM
For compound 4 the middle estimate is 1.5-fold (0.19 log units) above the measured one; measured number inside the range.
By their numbers in this assay, from the lowest: compounds 4, 3, 2 and 1 (each within the scatter of the next, the first and the last beyond it).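

Working notes: in this assay, an aryl group at this position keeps the series in range, with a 1.8-fold lower number from compound 3 to compound 4 (0.26 log units; within the scatter) against the cyclopropyl analogue. Among the compounds shown here, two steps, a 2.1-fold lower number from compound 2 to compound 4 (0.32 log units; beyond the scatter) and a 2.8-fold lower number from compound 1 to compound 4 (0.45 log units; beyond the scatter), are the first at this position to pass beyond the scatter, so 4-methoxyphenyl separates from tert-butyl and butyl where the saturated groups did not separate from one another. No evidence on the origin of these steps is available.

Open, from the compounds shown here alone, is whether the phenyl ring or its methoxy group carries the step. An unsubstituted phenyl, or an amine or carboxylic acid in place of the methoxy group, would address this.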